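A Methyl for a Hydroxy in a Level Series

This account rests on a few compounds, and the source may have more. Where it says the series, first, only, none or still open, it means among the compounds named here.

In a functional assay on B16-F10 cells (Mus musculus) for cytotoxicity (a lower number here means a stronger inhibitor, a higher number a weaker inhibitor), compound 3 `O=c1oc2ccccc2c2nc3c(ccc4cc[nH]c43)c(-c3ccc(O)cc3)c12` gives 70700 nM, level with compound 1 `O=c1oc2ccccc2c2nc3c(ccc4cc[nH]c43)c(-c3ccc(Br)cc3)c12` at 70700 nM and compound 2 `O=c1oc2ccccc2c2nc3c(ccc4cc[nH]c43)c(-c3c(Cl)cccc3Cl)c12` at 70700 nM. Compound 4 `Cc1ccc(-c2c3ccc4cc[nH]c4c3nc3c2c(=O)oc2ccccc23)cc1` shares their core and carries methyl in place of hydroxy on an aromatic carbon, para to a large group (methyl in place of hydroxy on an aromatic carbon). Going by the values given here, three measured steps bear on this change. The nearest swaps hydroxy in for bromo at that kind of carbon, no change at the digits printed from compound 1 to compound 3 (within the scatter). The two others exchange the whole substituted phenyl group, no change at the digits printed from compound 1 to compound 2 (within the scatter) and no change at the digits printed from compound 2 to compound 3 (within the scatter). None of these three moved the value, so no change beyond the scatter is expected in this assay. The expected step is no change at the digits printed from compound 3 to compound 4 (within the scatter). For compound 4 the estimated value is 70700 nM, within an expected range of 35000 nM to 100000 nM.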

Compound 4, half-maximal inhibitory concentration: 70700 nM
Beside the measured number, compound 4's estimate shows no gap at the digits printed; low and high end bracket the measured number.
By their numbers in this assay, from the lowest: compounds 1, 2, 3 and 4 (each within the scatter of the next).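

In this assay, hydroxy on this ring can be replaced by methyl, which has no hydrogen-bond donor or acceptor, and the value holds (no change at the digits printed from compound 3 to compound 4 (within the scatter)). Methyl also reads the same as bromo at this place (no change at the digits printed from compound 1 to compound 4 (within the scatter)), and the 4-methylphenyl group reads the same as the 2,6-dichlorophenyl group (no change at the digits printed from compound 2 to compound 4 (within the scatter)), so a plain carbon group now joins the substituents that leave the value level. From the compounds shown here alone, whether an amine, a carboxylic acid or a longer chain at this place would move the value stays open. Nothing in hand gives a reason for this level result.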